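The source may report more compounds than this note shows. Statements on the series, on what has been measured and on what is new or still open speak of the compounds shown alone.

Values in a physicochemical assay for solubility, read by spectrophotometry, with a stated time of 24 h, at pH 7.4 (on this read-out higher numbers stand for higher solubility and lower numbers for lower solubility), so far
- compound 1 `CN(C)c1ccc(C(=O)N/N=C/c2cccc(C(=O)O)c2)cc1` gives > 70000 nM (a limit)
- compound 2 `CN(/N=C/c1cccc(C(=O)O)c1)C(=O)c1ccc(N(C)C)cc1` gives > 67000 nM (a limit)
- compound 3 `CN(C)c1ccc(C(=O)N/N=C/c2ccc(C(=O)NO)cc2)cc1` gives 15000 nM (a number)

Among the compounds with values here, compound 3 at 15000 nM holds the only true number. The other two values are limits. Compound 4 `CN(/N=C/c1ccc(C(=O)NO)cc1)C(=O)c1ccc(N(C)C)cc1` differs from compound 3 in one place (methyl in place of hydrogen on an amide-type nitrogen), with methyl in place of hydrogen on an amide-type nitrogen.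

The same change occurs once among the measured compounds, as a step that the two limits leave unreadable from compound 1 to compound 2, so it gives no size to carry over. Compound 2, which carries the methyl, reports > 67000 nM as a limit, so that pair shows no drop to a measurable number. That is thin support from a single pair, and no step beyond the usual scatter is expected in this assay here. The expected 1.3-fold higher number from compound 3 to compound 4 (0.12 log units; within the scatter) is small and leans slightly upward. In this assay compound 4 is estimated at 20000 nM, with 7000 nM to 60000 nM as the expected range.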

Compound 4, solubility: > 64000 nM
Compound 4 was reported as a limit (the forecaster's own chance of this, stated with the estimate: 10%); middle value at least 3.2-fold (0.50 log units) away from the limit.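

In this assay, methyl in place of hydrogen on the amide-type nitrogen now has a readable direction and a lower bound on its size, as an at least 4.2-fold higher number from compound 3 to compound 4 (0.63 log units; beyond the scatter). The earlier pair, compound 1 and compound 2, could not be read for this change, as both of its values are limits. The step here is only a lower bound, since the value of compound 4 is itself a limit and not a number: the limit of > 64000 nM in this assay, at which 1 of the 4 values shown sits.

On these data alone, the true value of compound 4, and with it the full size of the step, stays open, and a single readable pair sets no pattern beyond compound 3 and compound 4. Also open, as far as these compounds go, is how an ethyl or a longer chain on this amide-type nitrogen would read in this assay against compound 3 at 15000 nM.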